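Series notes: the step from compound 2 to compound 3

The source may hold more compounds than are shown below. What is called first, only, known or untested is meant among the compounds shown, and "the series" means these compounds.

compound 1 `CCOC(=O)c1ccc(-c2ccc(OCC)cc2)o1`: 93%
compound 2 `CCOc1ccc(-c2cccc(S(=O)(=O)NC)c2)cc1`: 47%

In an assay on COS-7 cells for inhibition of patatin-like phospholipase domain-containing protein 2 (Mus musculus), tested at 200 uM (a lower number here means less inhibition, a higher number more inhibition at the concentration tested (going by the name of the read-out)), compound 1 gives 93%. In the same assay compound 2 gives 47%. Within the data shown here, compound 2 stands lowest of the two numbers measured so far; its nearest neighbour is compound 1, and the gap between the two lies beyond the scatter. Among the measured compounds shown here, no two measured compounds differ in a single place, so no single-point step is known in this assay to serve as a guide.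

Compound 3 `CCOc1ccc(-c2cccc(NC(=O)N(C)C)c2)cc1` has not yet been measured. It differs from compound 2 in one place: (dimethylcarbamoyl)amino in place of methylsulfamoyl on an aromatic carbon. For the measured compounds named here, with no comparable step measured in this assay, the expected step is a number 2 percentage points lower from compound 2 to compound 3 (within the scatter), of uncertain direction and probably not beyond the scatter. Compound 3 is therefore expected to give about 45% in this assay, with a range from 15% to 75%.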

Compound 3, a percentage reported as inhibition, at one concentration (the size of the read-out at that concentration, not a potency): 68%
For compound 3 the middle estimate is 23 percentage points below the measured one, and the stated range covers the measured number.
By their numbers in this assay, from the lowest: compound 2; then compound 3; then compound 1.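

In this assay the aromatic carbon carrying the methylsulfamoyl group of compound 2 now has its first measured single-place change: (dimethylcarbamoyl)amino in its place gives a number 21 percentage points higher from compound 2 to compound 3 (beyond the scatter) in a modest step. This position on the shared core therefore responds to the group it carries, and a sulfur-bearing group is not needed there for the read-out at the tested concentration. This single pair cannot separate the contributions of the features that differ between the two groups, and no measurement at hand bears on a cause.

Still open, going by these compounds, is how a carboxylic acid, an unsubstituted amine or a longer chain at this aromatic carbon would compare. Also open, on these data alone, is how much of the step depends on the two methyl groups of the (dimethylcarbamoyl)amino group.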